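The source may report more compounds than this note shows. Statements on the series, on what has been measured and on what is new or still open speak of the compounds shown alone.

Compound 3 `O=C(NCCNc1nccc(-c2c(-c3cccc(F)c3)nc3sccn23)n1)c1c(F)cccc1F` gives the lowest number of the three measured in a functional assay on A-375 cells (Homo sapiens) for cytotoxicity, read by MTT assay (on this read-out higher numbers stand for weaker inhibition and lower numbers for stronger inhibition), at 2700 nM. Compound 1 `O=S(=O)(NCCCNc1nccc(-c2c(-c3cccc(F)c3)nc3sccn23)n1)c1cccc(F)c1` gives 13700 nM and compound 2 `O=S(=O)(NCCCNc1nccc(-c2c(-c3cccc(F)c3)nc3sccn23)n1)c1ccc(Br)cc1` gives 7040 nM. Compound 4 `O=S(=O)(NCCNc1nccc(-c2c(-c3cccc(F)c3)nc3sccn23)n1)c1ccc(Cl)cc1` differs from compound 3 by (4-chlorophenyl)sulfonyl in place of (2,6-difluorophenyl)carbonyl on an amine nitrogen. Going by the values given here, the steps that bear on this are a 5.1-fold lower number from compound 1 to compound 3 (0.71 log units; beyond the scatter) and a 2.6-fold lower number from compound 2 to compound 3 (0.42 log units; beyond the scatter), both moving toward the amide and the shorter chain at once. Compound 4 keeps the shorter chain but returns to a sulfonyl group, so the expected step is a 2.2-fold higher number from compound 3 to compound 4 (0.35 log units; beyond the scatter), a modest rise in the number that roughly undoes the change seen from compound 2. Compound 4 is therefore estimated at 6000 nM in this assay, with a range from 2500 nM to 15000 nM.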

Compound 4, half-maximal inhibitory concentration: 18600 nM
The estimate for compound 4 lay 3.1-fold (0.49 log units) below the measured number, and the stated range ends below it.
By their numbers in this assay, from the lowest: compound 3; then compounds 2, 1 and 4 (each within the scatter of the next, the first and the last beyond it).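

On the same short chain in this assay, the change from carbonyl to sulfonyl alone gives a clear loss (a 6.9-fold higher number from compound 3 to compound 4 (0.84 log units; beyond the scatter)), which ties the low number of compound 3 to its (2,6-difluorophenyl)carbonyl group and not to the shorter chain by itself. Among the sulfonyl compounds, the shorter chain brings no gain (a 2.6-fold higher number from compound 2 to compound 4 (0.42 log units; beyond the scatter); a 1.4-fold higher number from compound 1 to compound 4 (0.13 log units; within the scatter)), and the second of these steps lies within the scatter. No measurement here gives a cause for the difference.

Going by these compounds, whether the difference comes from the carbonyl or from the fluorines remains open. A plain benzoyl group or a (2,6-difluorophenyl)sulfonyl group on this short chain would separate the two.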